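Fluoro gives way to methyl: compound 2 to compound 3

The source may hold more compounds than are shown below. What is called first, only, known or untested is meant among the compounds shown, and "the series" means these compounds.

Of the compounds shown here, two have been measured so far. In a functional assay on HL-60 cells (Homo sapiens) for cytotoxicity, with a stated time of 24 h (a lower number here means that less compound is tolerated, a higher number that more compound is tolerated), compound 2 (`O=C1/C(=C/c2ccc(F)cc2)CCC/C1=C\c1cccc([N+](=O)[O-])c1`) gives 1000 nM and so holds the lower of the two numbers, while compound 1 (`O=C1/C(=C/c2ccc(Cl)cc2)CCC/C1=C\c1ccccc1[N+](=O)[O-]`) gives 7600 nM in the same test. That gap lies beyond the usual scatter. Compound 3 (`Cc1ccc(/C=C2\CCC/C(=C\c3cccc([N+](=O)[O-])c3)C2=O)cc1`) departs from compound 2 in one place (methyl in place of fluoro on an aromatic carbon): methyl in place of fluoro on an aromatic carbon, para to a large group. For the measured compounds named here, no pair of measured compounds differs in one place only, so the data offer no direct measure of this change. The step expected in this assay is a 1.5-fold higher number from compound 2 to compound 3 (0.18 log units; within the scatter) and is estimated to stay within the usual scatter. Compound 3 is estimated to read 1500 nM with an expected range from 600 nM to 4000 nM for the measurement to come.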

Compound 3, half-maximal cytotoxic concentration: 38000 nM
Compound 3: middle estimate off by 25-fold (1.40 log units), on the low side; the measured number lies above the stated range.
By their numbers in this assay, from the lowest: compound 2; then compound 1; then compound 3.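

For the compounds shown here, the exchange of fluoro for methyl on this aromatic carbon, para to a large group, gives the first single-place step that can be read in this assay, and a 38-fold higher number from compound 2 to compound 3 (1.58 log units; beyond the scatter) shows that this position is not indifferent to the change. One heavy atom is swapped, with no ring, hydrogen-bond donor, hydrogen-bond acceptor or net charge entering or leaving, yet going from 4-fluorophenyl to 4-methylphenyl moves the number well beyond the scatter. Nothing at hand explains the size of this step.

Going by these compounds, whether an ethyl group, a methoxy group or an amine at the same place would also raise the number remains open. So does whether the exchange of fluoro for methyl would give a similar step with the nitro group placed as in compound 1.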